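Swapping the aryl ring on an inactive propyl analogue

The compounds below may be only part of what the source reports. "The series", "measured", "known", "first", "only" and "open" are said of these compounds alone.

compound 1 `Cc1ccccc1OS(=O)(=O)c1ccc(N2CCN(C)C2=O)cc1` gives 4800 nM
compound 2 `COc1cc(OC)cc(OS(=O)(=O)c2ccc(N3CCN(C)C3=O)cc2)c1` gives 190 nM
compound 3 `CCCN1CCN(c2ccc(S(=O)(=O)Oc3ccccc3C)cc2)C1=O` gives > 100000 nM

Three compounds share a core and were tested in a functional assay on HT-29 cells (Homo sapiens) for antiproliferative activity, read by sulforhodamine B assay, with a stated time of 48 h; on this read-out lower numbers stand for stronger inhibition and higher numbers for weaker inhibition. Compound 1 gives 4800 nM, and compound 2, which carries a differently substituted aryl ring, gives a lower number, 190 nM. Compound 3 is a different case: its result is not a number but a limit of the assay, > 100000 nM, so it stands at the limit of > 100000 nM in this assay, at which 1 of the 3 values shown sits, and only a floor for its true value is known.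

Going by the values given here, the one step that can be followed is an at least 20-fold higher number from compound 1 to compound 3 (1.31 log units; beyond the scatter), and it is large: lengthening the chain on the ring nitrogen pushes the number up to the limit of the assay.

Compound 4 `CCCN1CCN(c2ccc(S(=O)(=O)Oc3ccc(Cl)cc3)cc2)C1=O` keeps that longer chain and differs from compound 3 only in 4-chlorophenyl in place of 2-methylphenyl on an oxygen. Among the compounds with values here, no measured pair shows this exact change alongside the longer chain, so there is no basis for expecting the number to move beyond the scatter, and the step of a number no higher from compound 3 to compound 4 (the limit leaves the size open) is expected to be essentially flat. Compound 4 is therefore estimated at 100000 nM, with a range from 20000 nM to 300000 nM, and it may well again return only a limit.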

Compound 4, half-maximal inhibitory concentration: 15000 nM
For compound 4 the middle estimate is 6.7-fold (0.82 log units) above the measured one, outside the stated range (below it).
By their numbers in this assay, from the lowest: compound 2; then compound 1; then compound 4. At a limit, above all of these: compound 3.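

The longer propyl chain on the ring nitrogen does not rule out a measurable result in this assay: 4-chlorophenyl in place of 2-methylphenyl on an oxygen gives an at least 6.6-fold lower number from compound 3 to compound 4 (0.82 log units; beyond the scatter). The earlier compounds shown here showed only that this chain could take the number to the limit of the assay, whereas this step shows that the group on the oxygen whose other neighbour is the sulfonyl sulfur still matters with the propyl chain in place. The true size of the step remains unknown because compound 3 is recorded only as a limit: the limit of > 100000 nM in this assay, at which 1 of the 4 values shown sits.

Since the methyl group leaves and the chlorine enters in a single change, these compounds cannot tell whether the lower number comes from losing one, gaining the other, or both. From the compounds shown here alone, it also remains open whether 4-chlorophenyl would have a similar effect with the shorter methyl group on the ring nitrogen, and how the number would respond to a still longer butyl chain there or to an aryl ring carrying a carboxylic acid.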